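The source may report more compounds than this note shows. Statements on the series, on what has been measured and on what is new or still open speak of the compounds shown alone.

Measured in a functional assay on MDA-MB-231 cells (Homo sapiens) for cytotoxicity, read by MTT assay, with a stated time of 48 h; a lower number here means a stronger inhibitor, a higher number a weaker inhibitor:
Compound 1 `Fc1ccc(C(CCCCOCc2ccc(Oc3ccc(Cl)cc3)cc2)c2ccc(F)cc2)cc1`: > 20000 nM
Compound 2 `Cc1ccc(NC(=O)NCCCCC(c2ccc(F)cc2)c2ccc(F)cc2)cc1`: > 20000 nM

Both entries are limits of the assay and not numbers: the limit of > 20000 nM in this assay, at which 2 of the 2 values shown sit. Compound 2 therefore has no number of its own, and in this assay compound 2 gives only the limit > 20000 nM. Among the measured compounds shown here, no pair of measured compounds offers a step that could serve as a guide.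

The next compound is compound 3 `Nc1ccc(NC(=O)NCCCCC(c2ccc(F)cc2)c2ccc(F)cc2)cc1`. It keeps the structure of compound 2 except for one place, with amino in place of methyl on an aromatic carbon, para to a large group: amino in place of methyl on an aromatic carbon. In other words, 4-methylphenyl becomes 4-aminophenyl.

The expectation in this assay is for no step beyond the scatter, with any real shift more likely toward stronger inhibition. This expectation rests on compound 2 and its limit of > 20000 nM. The estimated step of a number no higher from compound 2 to compound 3 (the limit leaves the size open) is expected to be small, and another limit is the likeliest report. For compound 3 the estimated value is 20000 nM, with an expected range from 8000 nM to 40000 nM.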

Compound 3, half-maximal inhibitory concentration: > 20000 nM
Compound 3 was reported as a limit (the forecaster's own chance of this, stated with the estimate: 65%); the middle value sits exactly at the limit.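

Compound 2 and compound 3 are both reported only as limits in this assay, and no step can be read between them. The compounds shown leave open how far each lies beyond that limit, and whether amino in place of methyl shifts the read-out at all: the limit of > 20000 nM in this assay, at which 3 of the 3 values shown sit.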